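From thiophen-2-yl to 4-chlorophenyl in a flat series

A few compounds are considered here, and "the series" means these few. Any claim that something is new, unique, unknown or untested is made for them only; others in the source may bear on it.

Compound 1 `CCOC(=O)c1cnn(-c2nc(-c3ccc(N(C)C)cc3)c(C#N)c(=O)n2C)c1N` gives 111 ug/mL here
Compound 2 `CCOC(=O)c1cnn(-c2nc(-c3ccco3)c(C#N)c(=O)n2C)c1N` gives 116 ug/mL here
Compound 3 `CCOC(=O)c1cnn(-c2nc(-c3cccs3)c(C#N)c(=O)n2C)c1N` gives 97 ug/mL here

All three numbers come from a functional assay on microsomes for inhibition, with a stated time of 1 h (a lower number here means a stronger inhibitor, a higher number a weaker inhibitor), and they barely differ. Compound 3 cannot be told apart from the other two, with a 1.1-fold lower number from compound 1 to compound 3 (0.06 log units; within the scatter) and a 1.2-fold lower number from compound 2 to compound 3 (0.08 log units; within the scatter) as the gaps, both within the scatter.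

Compound 4 `CCOC(=O)c1cnn(-c2nc(-c3ccc(Cl)cc3)c(C#N)c(=O)n2C)c1N`, still unmeasured, has 4-chlorophenyl in place of thiophen-2-yl on an aromatic carbon. Swaps at this same place have so far moved little, and a 1.0-fold higher number from compound 1 to compound 2 (0.02 log units; within the scatter) joins those two gaps within the scatter. Within the data shown here, compound 1, which carries 4-(dimethylamino)phenyl, gives 111 ug/mL, so the one measured phenyl group does not stand apart from the two five-membered rings. Among the measured compounds shown here, no compound with chlorine has been measured yet.

No step beyond the scatter is therefore expected, and the estimated move is a 1.1-fold higher number from compound 3 to compound 4 (0.03 log units; within the scatter) in this assay, with no clear direction. For compound 4 the estimated value is 105 ug/mL, with an expected range of 55 ug/mL to 190 ug/mL around it.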

Compound 4, half-maximal inhibitory concentration: 88 ug/mL
Estimate against measurement, compound 4: 1.2-fold (0.08 log units) above; low and high end bracket the measured number.
By their numbers in this assay, from the lowest: compounds 4, 3, 1 and 2 (each within the scatter of the next).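

In this assay, among these compounds, the first compound with chlorine falls in with the rest of the series (a 1.1-fold lower number from compound 3 to compound 4 (0.04 log units; within the scatter)), (a 1.3-fold lower number from compound 2 to compound 4 (0.12 log units; within the scatter)) and (a 1.3-fold lower number from compound 1 to compound 4 (0.10 log units; within the scatter)), and all three steps are within the scatter. This position now holds a six-membered aromatic ring of carbon only bearing chloro, as well as the same ring bearing dimethylamino and two five-membered aromatic rings, and the numbers for these four groups cannot be told apart; the last step also shows that exchanging dimethylamino for chloro on the phenyl ring leaves the result within the scatter. No measurement at hand offers an explanation for this flat result.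

Every group so far at this place is an aromatic ring. From the compounds shown here alone, whether an amine, a longer alkyl chain or a phenyl ring carrying a carboxylic acid would move the number beyond the scatter remains open.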